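Cytotoxicity notes: aryl swap on the carbonyl of compound 1

This account rests on a few compounds, and the source may have more. Where it says the series, first, only, none or still open, it means among the compounds named here.

Of the compounds shown here, two have been read in an ADME assay on MT4 cells (Homo sapiens) for cytotoxicity, read by MTT assay; on this read-out higher numbers stand for lower toxicity in this test and lower numbers for higher toxicity in this test. Compound 1 `O=C1c2ccccc2C(=O)N1CCOC(=S)N(C(=O)c1ccccc1[N+](=O)[O-])c1ccc(Cl)cc1` gives 21000 nM, the lower of the two numbers, and compound 2 `O=C1c2ccccc2C(=O)N1CCOC(=S)N(C(=O)c1ccc(Cl)c(Cl)c1)c1ccc(Cl)cc1` gives 35000 nM; the two lie within the scatter of each other, so no order between them can be read. Going by the values given here, the one measured step on the same carbonyl carbon, a 1.7-fold higher number from compound 1 to compound 2 (0.22 log units; within the scatter), did not move this assay beyond its scatter.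

Compound 3 `COc1cccc(OC)c1C(=O)N(C(=S)OCCN1C(=O)c2ccccc2C1=O)c1ccc(Cl)cc1` differs from compound 1 by 2,6-dimethoxyphenyl in place of 2-nitrophenyl on a carbonyl carbon. Among the compounds with values here, the only comparable step, from compound 1 to compound 2, was within the scatter, and nothing else bears on this position, so the expectation for compound 3 in this assay is a number near that of compound 1, with a 1.2-fold higher number from compound 1 to compound 3 (0.08 log units; within the scatter) taken as no change beyond the scatter. Compound 3 is therefore estimated at 25000 nM, with a range from 10000 nM to 60000 nM.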

Compound 3, half-maximal cytotoxic concentration: 69000 nM
The estimate for compound 3 lay 2.8-fold (0.44 log units) below the measured number; the measured number lies above the stated range.
By their numbers in this assay, from the lowest: compounds 1, 2 and 3 (each within the scatter of the next, the first and the last beyond it).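

In this assay, this carbonyl position now shows a step beyond the scatter: 2,6-dimethoxyphenyl in place of 2-nitrophenyl gives a 3.3-fold higher number from compound 1 to compound 3 (0.52 log units; beyond the scatter) and points towards lower toxicity in this test, though the step is modest. The same group in place of 3,4-dichlorophenyl gives a 2.0-fold higher number from compound 2 to compound 3 (0.29 log units; within the scatter) and does not separate compound 3 from compound 2, so the aryl swap is resolved only for the pair of compound 1 and compound 3. No supporting data bear on the reason for this step.

From the compounds shown here alone, whether one methoxy group on the phenyl ring would carry the same step as the 2,6-dimethoxyphenyl group remains open. Going by these compounds, an amine or a carboxylic acid on that ring also remains untested against these numbers, and so does an aliphatic group such as cyclohexyl in place of the aryl group on this carbonyl carbon.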